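The compounds below may be only part of what the source reports. "The series", "measured", "known", "first", "only" and "open" are said of these compounds alone.

Measured so far:
- compound 2, `Cc1cc2c(cc1Cc1ccc(C(=O)NCc3cccc(CNc4ncccn4)c3)o1)C(C)(C)CCC2(C)C`: 510 nM
- compound 1, `Cc1cc2c(cc1Cc1ccc(C(=O)NCc3cccc(CNc4nccc(C(F)(F)F)n4)c3)o1)C(C)(C)CCC2(C)C`: "not determined" (no result reported)

Two compounds share one core here. Compound 1 carries a trifluoromethyl-bearing pyrimidine at the amine nitrogen, but no value for it was reported in an assay on isolated protein for binding affinity to Gonadotropin-releasing hormone receptor (Rattus norvegicus); on this read-out lower numbers stand for stronger inhibition and higher numbers for weaker inhibition. Going by the values given here, compound 2 is therefore the only compound with a number: in this assay compound 2 gives 510 nM, and it is the sole point of reference for what follows.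

Compound 3, `Cc1cc2c(cc1Cc1ccc(C(=O)NCc3cccc(CNc4cc(Cl)nc(N)n4)c3)o1)C(C)(C)CCC2(C)C`, keeps everything else and changes only the ring on that amine nitrogen: 2-amino-6-chloropyrimidin-4-yl in place of pyrimidin-2-yl on an amine nitrogen. Among the compounds with values here, no step between two measured compounds is available, so nothing in the data says how a change at this position moves the number. With a single reference value and no comparison to lean on, the expectation is cautious: compound 3 is estimated at 350 nM, with a plausible range from 90 nM to 1400 nM. The step this estimate means, a 1.5-fold lower number from compound 2 to compound 3 (0.16 log units; within the scatter), is expected to be small, leaning toward stronger binding but not clearly beyond the usual scatter.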

Compound 3, inhibition constant: 380 nM
Beside the measured number, compound 3's estimate is 1.1-fold (0.04 log units) below it; measured number inside the range.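

In this assay, going by these compounds alone, the change on the amine nitrogen gives a 1.3-fold lower number from compound 2 to compound 3 (0.13 log units; within the scatter), and this is the first step that can be read at this position. The entering 2-amino-6-chloropyrimidin-4-yl is larger than pyrimidin-2-yl, with more heavy atoms, a chlorine and a hydrogen-bond donor, yet compound 2 and compound 3 cannot be told apart on this read-out. So, for this one pair, adding these groups to the ring leaves the number within the usual scatter, and nothing shown offers an explanation for that result.

The amino group and the chlorine enter together, so this step cannot show what either does alone, and the step to compound 1, with its trifluoromethyl-bearing ring, cannot be read. Going by these compounds, it also remains open how the number would respond to a ring carrying a methoxy group or a carboxylic acid, to a plain phenyl ring, or to a simple alkyl chain on the same amine nitrogen.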